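The source may hold more compounds than are shown below. What is called first, only, known or untested is meant among the compounds shown, and "the series" means these compounds.

Compound 1 `CC1=CC[C@@H]([C@@](C)(O)CCCC(C)(C)NC=S)CC1`: > 100000 nM
Compound 2 `COc1ccc(/C=N\NC(=S)NC(C)(C)CCC[C@](C)(O)[C@@H]2CC=C(C)CC2)cc1`: > 100000 nM

In a functional assay on MCF7 cells (Homo sapiens) for cytotoxicity, read by sulforhodamine B assay (a higher number here means that more compound is tolerated, a lower number that less compound is tolerated), compound 1 gives only the limit > 100000 nM, not a measured number. Compound 2 likewise reaches only the limit > 100000 nM in this assay; it stands at the limit of > 100000 nM in this assay, at which 2 of the 2 values shown sit, so no number is known for it. Compound 3 `CC1=CC[C@@H]([C@@](C)(O)CCCC(C)(C)NC(=S)N/N=C\c2ccc(Cl)cc2)CC1` differs from compound 2 in a single place: chloro in place of methoxy on an aromatic carbon. Nothing measured here points to a step beyond the usual scatter from such a change. The step of a number no higher from compound 2 to compound 3 (the limit leaves the size open) is therefore expected to be none beyond the scatter. Compound 3 is estimated at 100000 nM, within 30000 nM to 300000 nM, most likely again reported only as a limit.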

Compound 3, concentration lethal to 50% of the cells: 44300 nM
Compound 3: the middle estimate sits 2.3-fold (0.35 log units) above what was measured, within the range that was stated.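

In this assay, chloro in place of methoxy on an aromatic carbon para to a large group gives an at least 2.2-fold lower number from compound 2 to compound 3 (0.35 log units; beyond the scatter), so this position is not silent to change. Among the compounds shown here, compound 3 is the first compound here to give a measured number rather than a limit. The full size of the step stays open, as compound 2 gives no number: the limit of > 100000 nM in this assay, at which 2 of the 3 values shown sit.

The methoxy leaves and the chloro enters in the same step. This pair cannot tell the two apart. Going by these compounds, what a fluoro, a nitrile or an amine at this position would give remains open.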